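Trimming a Methoxy Group on a Pyrazole Chalcone Series

The source may hold more compounds than are shown below. What is called first, only, known or untested is meant among the compounds shown, and "the series" means these compounds.

Compound 1 `COc1cc(-c2cc(/C=C/C(=O)c3ccc(N)cc3)[nH]n2)cc(OC)c1OC`: 94%
Compound 2 `COc1ccc(-c2cc(/C=C/C(=O)c3ccc(N)cc3)[nH]n2)cc1OC`: 95%
Compound 3 `COc1cc(C(=O)/C=C/c2cc(-c3cc(OC)c(OC)c(OC)c3)n[nH]2)cc(OC)c1OC`: 94%

All three were tested in a functional assay on U-251 cells (Homo sapiens) for cytotoxicity, read by sulforhodamine B assay, with a stated time of 48 h, tested at 0.1 uM; a higher number here means a weaker effect of the compound at the concentration tested, a lower number a stronger effect. Compound 1 gives 94%, and compound 2, which differs by hydrogen in place of methoxy on an aromatic carbon, gives 95%, a step of a number 1 percentage points higher from compound 1 to compound 2 (within the scatter). Compound 3 gives 94%; how the core of compound 3 differs from that of compound 1 is not broken down here, and its value is level with compound 1 within the usual scatter.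

Compound 4 `COc1ccc(-c2cc(/C=C/C(=O)c3cc(OC)c(OC)c(OC)c3)[nH]n2)cc1OC` is not yet measured. It arises from compound 3 by hydrogen in place of methoxy on an aromatic carbon, the same change as from compound 1 to compound 2, at the same place. Because that earlier step was a number 1 percentage points higher from compound 1 to compound 2 (within the scatter), the step from compound 3 to compound 4 is expected to be a number 1 percentage points higher from compound 3 to compound 4 (within the scatter). Compound 4 is therefore estimated at 95%, likely between 85% and 102%.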

Compound 4, a percentage reported as activity, at one concentration (the size of the read-out at that concentration, not a potency): 92%
Compound 4: middle estimate off by 3 percentage points, on the high side, within the range that was stated.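

In this assay, hydrogen in place of methoxy gives a number 2 percentage points lower from compound 3 to compound 4 (within the scatter). Set beside the earlier step, the change looks the same on both cores: the same change on two cores in this assay, a number 1 percentage points higher (within the scatter) from compound 1 to compound 2 and a number 2 percentage points lower (within the scatter) from compound 3 to compound 4, 3 percentage points apart, within the scatter of two such steps This shows only that the change leaves the read-out within the scatter on these two cores at this one concentration; it does not show that a real effect carries from one core to another, as neither step is large enough to reveal one.

The compounds shown leave open whether another group at this place, such as a hydroxyl or a carboxylic acid, would move the read-out beyond the scatter. They also leave open how the change would behave on a core with a clearly stronger effect in this assay.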